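Furan-3-yl to Benzofuran-2-yl on Two Nucleoside Cores

The compounds below may be only part of what the source reports. "The series", "measured", "known", "first", "only" and "open" are said of these compounds alone.

Measured so far:
compound 1, `COc1ncnc2c1c(-c1ccoc1)cn2[C@@H]1O[C@H](CO)[C@@H](O)[C@H]1O`: 190 nM
compound 2, `COc1ncnc2c1c(-c1cc3ccccc3o1)cn2[C@@H]1O[C@H](CO)[C@@H](O)[C@H]1O`: 20900 nM
compound 3, `Nc1nc(N)c2c(-c3ccoc3)cn([C@@H]3O[C@H](CO)[C@@H](O)[C@H]3O)c2n1`: > 20000 nM

In a functional assay on K562 cells (Homo sapiens), read by MTT assay, with a stated time of 72 h (a lower number here means a stronger inhibitor, a higher number a weaker inhibitor), compound 1 gives 190 nM. Compound 2 gives 20900 nM in this assay. The change between them is 1-benzofuran-2-yl in place of furan-3-yl on an aromatic carbon, and the step is a 110-fold higher number from compound 1 to compound 2 (2.04 log units; beyond the scatter).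

Compound 3 sits at a limit of this assay, > 20000 nM, which is not a number; one of the three values sits at the limit of > 20000 nM in this assay, at which 1 of the 3 values shown sits. How the core of compound 3 differs from the core of compound 1 is not broken down here.

Compound 4, `Nc1nc(N)c2c(-c3cc4ccccc4o3)cn([C@@H]3O[C@H](CO)[C@@H](O)[C@H]3O)c2n1`, is not yet measured. It differs from compound 3 by 1-benzofuran-2-yl in place of furan-3-yl on an aromatic carbon, the same change as from compound 1 to compound 2, at the same kind of place.

Among the measured compounds shown here, since the one measured instance of this change weakened inhibition strongly, as a 110-fold higher number from compound 1 to compound 2 (2.04 log units; beyond the scatter) shows, and compound 3 already sits at a limit, compound 4 is expected to remain at or beyond that limit. The expected step is a step that the limit leaves unreadable from compound 3 to compound 4, resting on a 110-fold higher number from compound 1 to compound 2 (2.04 log units; beyond the scatter). For compound 4 the estimate in this assay is 100000 nM, within 20000 nM to 2000000 nM, most likely reported only as a limit.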

Compound 4, half-maximal inhibitory concentration: 18600 nM
For compound 4 the middle estimate is 5.4-fold (0.73 log units) above the measured one, outside the stated range (below it).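

In this assay compound 3 stands at > 20000 nM, which is a limit and not a number. On that core the change from furan-3-yl to 1-benzofuran-2-yl reads as an at least 1.0-fold lower number from compound 3 to compound 4 (0.03 log units; that floor lies within the scatter), so the large weakening seen on the core of compound 1 does not carry over at the same size, and the two steps differ: the same change on two cores in this assay, a 110-fold higher number (2.04 log units; beyond the scatter) from compound 1 to compound 2 and an at least 1.0-fold lower number (0.03 log units; that floor lies within the scatter) from compound 3 to compound 4, at least 110-fold (2.07 log units) apart, beyond the scatter of two such steps This rests on a single pair per core and gives only a floor for the second step, so it shows that the effect of the change depends on the core in these four compounds, but it neither gives the true size of the step on the core of compound 3 nor sets a rule for the wider series.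

The compounds shown leave open which feature of the two cores sets the steps apart. Also open, as far as these compounds go, is how either core responds when an amine or a longer chain stands on the aromatic carbon that bears the furan-3-yl group.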